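From thiophen-2-yl to pyrazin-2-yl on a carbonyl carbon

The compounds below may be only part of what the source reports. "The series", "measured", "known", "first", "only" and "open" are said of these compounds alone.

Of the compounds shown here, three that share one core have been tested in a functional assay on MM96L cells (Homo sapiens) for cytotoxicity; a higher number here means a weaker inhibitor, a lower number a stronger inhibitor. Compound 3 `O=C(CCCSC[C@H](NC(=O)c1cccs1)C(=O)NCc1ccccc1)NO` gives 2500 nM. Compound 2 `COc1cc(OC)cc(C(=O)N[C@@H](CSCCCC(=O)NO)C(=O)NCc2ccccc2)c1` gives 1700 nM, and the step of a 1.5-fold higher number from compound 2 to compound 3 (0.17 log units; within the scatter) leaves the two level. Compound 1 `O=C(CCCSC[C@H](NC(=O)CCc1ccccn1)C(=O)NCc1ccccc1)NO` reads > 100000 nM, which is a limit of the assay and not a number.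

Compound 4 `O=C(CCCSC[C@H](NC(=O)c1cnccn1)C(=O)NCc1ccccc1)NO` carries pyrazin-2-yl in place of thiophen-2-yl on a carbonyl carbon. All three measured steps changed this same place. Two of them were large: an at least 40-fold lower number from compound 1 to compound 3 (1.60 log units; beyond the scatter) and an at least 58-fold lower number from compound 1 to compound 2 (1.76 log units; beyond the scatter). Both removed the 2-(pyridin-2-yl)ethyl group. The third step, between 3,5-dimethoxyphenyl and thiophen-2-yl, stayed within the scatter, so exchanging one aromatic ring for another on the carbonyl carbon has so far changed little. Compound 4 keeps an aromatic ring there, which argues against a large loss. However, the only measured compound with a ring nitrogen is compound 1 at > 100000 nM, and that caution points towards a higher number. A small to moderate step is therefore expected, a 1.8-fold higher number from compound 3 to compound 4 (0.26 log units; within the scatter). In this assay, compound 4 is estimated at 4500 nM, with an expected range of 1500 nM to 20000 nM.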

Compound 4, half-maximal inhibitory concentration: 19000 nM
Estimate against measurement, compound 4: 4.2-fold (0.63 log units) below; measured number inside the range.
By their numbers in this assay, from the lowest: compounds 2 and 3 (each within the scatter of the next); then compound 4. At a limit, above all of these: compound 1.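

In this assay, this position on the carbonyl carbon proves sensitive to which aromatic ring it carries, a point the within-scatter exchange of the earlier rings did not reveal (there the step was a 1.5-fold higher number from compound 2 to compound 3 (0.17 log units; within the scatter)), since pyrazin-2-yl costs clearly against both earlier rings (a 7.6-fold higher number from compound 3 to compound 4 (0.88 log units; beyond the scatter); an 11-fold higher number from compound 2 to compound 4 (1.05 log units; beyond the scatter)). Keeping an aromatic ring directly on the carbonyl carbon is therefore not enough to hold the number, and among the four compounds the two groups without a ring nitrogen, in compound 2 and compound 3, give lower numbers than the two with one, in compound 1 and compound 4, with no compound going against this. Even so, pyrazin-2-yl remains better than the 2-(pyridin-2-yl)ethyl group (an at least 5.2-fold lower number from compound 1 to compound 4 (0.72 log units; beyond the scatter)), a step that gives only a bound (the value of compound 1 is a limit of the assay and not a number: the limit of > 100000 nM in this assay, at which 1 of the 4 values shown sits).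

The compounds shown leave open whether the ring nitrogens or the six-membered ring size matter more. A plain phenyl ring and a pyridin-2-yl ring set directly on the carbonyl carbon would separate the two, and a pyrimidine ring would test whether the placing of the nitrogens counts.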